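This account rests on a few compounds, and the source may have more. Where it says the series, first, only, none or still open, it means among the compounds named here.

Of the compounds shown here, three built on the same shared core have been measured in a functional assay for antagonist activity at transient receptor potential cation channel subfamily V member 1 (Homo sapiens), read by FLIPR and calcium flux; a higher number here means a weaker inhibitor, a lower number a stronger inhibitor. Compound 1 `O=C1COc2ccc(NC(=O)C3CCN(c4cc(F)c(F)c(F)c4)CC3)cc2N1` gives 59 nM. Compound 2 `Cc1cccc(N2CCC(C(=O)Nc3ccc4c(c3)NC(=O)CO4)CC2)c1C` gives 60 nM. Compound 3 `Cc1c(Cl)cccc1N1CCC(C(=O)Nc2ccc3c(c2)NC(=O)CO3)CC1` gives 100 nM. All three differ only in the aromatic group carried on the amine nitrogen in the ring, and the numbers sit close together: the step of a 1.7-fold higher number from compound 1 to compound 3 (0.23 log units; within the scatter) and the step of a 1.7-fold higher number from compound 2 to compound 3 (0.22 log units; within the scatter) both fall inside the scatter, as does the step of a 1.0-fold higher number from compound 1 to compound 2 (0.01 log units; within the scatter). Compound 3 therefore stands among its neighbours rather than apart from them.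

Compound 4 `O=C1COc2ccc(NC(=O)C3CCN(c4ccccc4C(F)(F)F)CC3)cc2N1` has not yet been measured in this assay. It differs from compound 3 in one place: 2-(trifluoromethyl)phenyl in place of 3-chloro-2-methylphenyl on an amine nitrogen in a ring. Among the measured compounds shown here, the steps that bear on this change are those already seen at the same position, where swapping one aromatic group for another moved the numbers by no more than the scatter. Because those steps a 1.7-fold higher number from compound 1 to compound 3 (0.23 log units; within the scatter) and a 1.7-fold higher number from compound 2 to compound 3 (0.22 log units; within the scatter) were so small, the expected step of a 1.1-fold lower number from compound 3 to compound 4 (0.05 log units; within the scatter) is also no larger than the scatter, in no particular direction. Compound 4 is therefore estimated at 90 nM, with a range from 35 nM to 250 nM.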

Compound 4, half-maximal inhibitory concentration: 380 nM
Compound 4: the middle estimate sits 4.2-fold (0.63 log units) below what was measured; the whole stated range lies below it.
By their numbers in this assay, from the lowest: compounds 1, 2 and 3 (each within the scatter of the next); then compound 4.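

In this assay, among the compounds shown here, the aromatic group on the amine nitrogen in the ring can no longer be treated as freely exchangeable: 2-(trifluoromethyl)phenyl in place of 3-chloro-2-methylphenyl gives a 3.8-fold higher number from compound 3 to compound 4 (0.58 log units; beyond the scatter) and is the first change at this position to lie beyond the scatter. The same group gives a 6.3-fold higher number from compound 2 to compound 4 (0.80 log units; beyond the scatter) when it replaces 2,3-dimethylphenyl and a 6.4-fold higher number from compound 1 to compound 4 (0.81 log units; beyond the scatter) when it replaces 3,4,5-trifluorophenyl, so compound 4 is the weaker inhibitor against each of the three earlier compounds, even though those three stay within the scatter of one another. Nothing in the data shown accounts for this loss of activity.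

Compounds 2 and 3 each carry two groups on the phenyl ring and compound 4 carries only one, so these compounds cannot separate the effect of trifluoromethyl itself from the effect of that difference in substitution. Going by these compounds, it also remains open how a plain phenyl group, or a phenyl carrying a methoxy group or a nitrile, would read at this position.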